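Working notes: from compound 3 to compound 4

The source may hold more compounds than are shown below. What is called first, only, known or untested is meant among the compounds shown, and "the series" means these compounds.

In an ADME assay on microsomes from liver (Homo sapiens) for metabolic stability, with a stated time of 30 min (on this read-out lower numbers stand for a less stable compound and higher numbers for a more stable compound), compound 1 (`CC(C)(C)[C@@H](CO)n1cc(C(=O)O)c(=O)c2cc(Cc3cccc(Cl)c3F)c(O)nc21`) gives 87% and compound 2 (`COc1nc2c(cc1NCc1ccc(F)cc1)c(=O)c(C(=O)O)cn2[C@H](CO)C(C)C`) gives 87% as well. Compound 3 (`COc1nc2c(cc1NCc1ccc(F)cc1)c(=O)c(C(=O)O)cn2[C@H](CO)C(C)(C)C`) has no usable number: its entry reads "not determined" (no result reported) and it therefore offers no direct starting value.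

Compound 4 (`COc1nc2c(cc1NCc1c(F)cc(F)cc1F)c(=O)c(C(=O)O)cn2[C@H](CO)C(C)(C)C`) differs from compound 3 as follows (2,4,6-trifluorophenyl in place of 4-fluorophenyl on a saturated chain carbon bound to a nitrogen on an aromatic ring) with 2,4,6-trifluorophenyl in place of 4-fluorophenyl on a saturated chain carbon bound to a nitrogen on an aromatic ring. Among the compounds with values here, no measured pair shows the effect of this change, so its size cannot be read from the data. Compound 2 at 87% is the nearest guide, and compound 4 is expected to stay within the scatter of that level, with no step in either direction. The read-out remains uncertain without a value for compound 3.

For compound 4 the estimated value in this assay is 84% with an expected range from 66% to 97% in repeat measurements.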

Compound 4, percent of the compound remaining: 75%
Compound 4: the middle estimate sits 9 percentage points above what was measured, within the range that was stated.
By their numbers in this assay, from the lowest: compound 4; then compounds 1 and 2 (each within the scatter of the next).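

No new step can be read between compound 3 and compound 4: compound 4 gives 75% in this assay, while compound 3 carries no number to set against it. Going by these compounds, what 2,4,6-trifluorophenyl in place of 4-fluorophenyl does to this read-out stays open. No supporting evidence bears on this result.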